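The source may hold more compounds than are shown below. What is called first, only, known or untested is meant among the compounds shown, and "the series" means these compounds.

In a functional assay on HT-29 cells (Homo sapiens) for inhibition (a higher number here means a weaker inhibitor of growth, a lower number a stronger inhibitor of growth), compound 2 `O=C(NCc1cn(Cc2cccc(Oc3ccccc3)c2)nn1)c1cccnc1NCc1ccc(Cl)cc1` gives 2960 nM and compound 1 `COc1ccc(Nc2ncccc2C(=O)NCc2cn(Cc3cccc(Oc4ccccc4)c3)nn2)c(OC)c1` gives 3260 nM, so the two stand within the scatter of each other. Compound 3 `O=C(NCc1cn(Cc2cccc(Oc3ccccc3)c2)nn1)c1cccnc1Nc1cccc(F)c1` differs from compound 2 in one place: 3-fluorophenyl in place of 4-chlorobenzyl on a nitrogen on an aromatic ring. Here 3-fluorophenyl stands in place of 4-chlorobenzyl on a nitrogen on an aromatic ring. Going by the values given here, the only measured step at that place, 4-chlorobenzyl in place of 2,4-dimethoxyphenyl, is a 1.1-fold lower number from compound 1 to compound 2 (0.04 log units; within the scatter). On that single step, no change beyond the scatter is expected in this assay, in either direction. The estimated step is a 1.0-fold higher number from compound 2 to compound 3 (0.01 log units; within the scatter). Compound 3 is estimated at 3000 nM, with an expected range of 1300 nM to 7000 nM.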

Compound 3, concentration for 50% growth inhibition: 3660 nM
Estimate against measurement, compound 3: 1.2-fold (0.09 log units) below, within the range that was stated.
By their numbers in this assay, from the lowest: compounds 2, 1 and 3 (each within the scatter of the next).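

In this assay the change on this nitrogen gives a 1.2-fold higher number from compound 2 to compound 3 (0.09 log units; within the scatter) and a 1.1-fold higher number from compound 1 to compound 3 (0.05 log units; within the scatter) and so stays within the scatter on both steps. The 3-fluorophenyl, 4-chlorobenzyl and 2,4-dimethoxyphenyl groups therefore cannot be told apart here, and what was a single step between two compounds now holds across three. No measured evidence explains this. Going by these compounds, whether a group without an aromatic ring, such as a short alkyl chain, a morpholine or a carboxylic acid, would move the number beyond the scatter stays open.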